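From a chlorobutenyl chain to a five-membered ring

This account rests on a few compounds, and the source may have more. Where it says the series, first, only, none or still open, it means among the compounds named here.

Going by the values given here, in a functional assay on L1210 cells (Mus musculus) for inhibition (a lower number here means a stronger inhibitor, a higher number a weaker inhibitor), compound 2 `Nc1ncnc2c1ncn2C/C=C\CCl` gives 22000 nM, the only actual number. Compound 1 `Nc1ccn(C/C=C/CO)c(=O)n1` reads > 550000 nM, which is a limit. Compound 3 `Cc1cn(CC#CCO)c(=O)[nH]c1=O` reads > 500000 nM, also a limit. Compound 4 `Nc1ncnc2c1ncn2C1C=CCO1` keeps the core of compound 2 and alters only the group on the aromatic nitrogen: a group of 5 heavy atoms (4 carbon, 1 oxygen; one five-membered non-aromatic ring with 1 hetero atom) in place of a group of 5 heavy atoms (4 carbon, 1 chlorine; no ring), on an aromatic nitrogen. The 4-chlorobut-2-en-1-yl chain leaves, and with it the only chlorine in the series. No measured step connects any of these compounds, so the expectation is loose. Weaker inhibition in this assay is expected for compound 4, resting on chlorine-free compound 3 with its limit of > 500000 nM. The step expected is a 9.1-fold higher number from compound 2 to compound 4 (0.96 log units; beyond the scatter). The estimated value for compound 4 is 200000 nM, with an expected range of 50000 nM to 600000 nM.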

Compound 4, half-maximal inhibitory concentration: > 500000 nM
Compound 4: a limit, no number; the forecaster's own chance of this, stated with the estimate: 45%; at least 2.5-fold (0.39 log units) between middle value and limit.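

At this position, on an aromatic nitrogen, the series gives its first readable change: in this assay, the five-membered non-aromatic ring in place of the 4-chlorobut-2-en-1-yl chain gives an at least 22-fold higher number from compound 2 to compound 4 (1.35 log units; beyond the scatter) and the shared core alone keeps no actual number. As far as these compounds go, the full size of this step stays unknown because compound 4 reads only as a limit: the limit of > 500000 nM in this assay, at which 2 of the 4 values shown sit.

From the compounds shown here alone, whether the chlorine, the open chain or the ring decides the loss stays open. A butyl chain or a 4-aminobut-2-en-1-yl chain on the same core would help to separate these.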